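Cycloheptyl in Place of Nitrophenyl: An Expected Binding Value

This account rests on a few compounds, and the source may have more. Where it says the series, first, only, none or still open, it means among the compounds named here.

Two compounds were measured in an assay on CHO cells for displacement of a labelled ligand from adenosine receptor A3 (Homo sapiens), read by scintillation counting, with a stated time of 120 min, tested at 10 uM; on this read-out higher numbers stand for more inhibition at the one concentration tested (going by the name of the read-out) and lower numbers for less inhibition:
compound 1 `Nc1scc(CN2CCN(c3ccc([N+](=O)[O-])cc3)CC2)c1C(=O)c1ccc(Cl)cc1` gives 2%
compound 2 `Nc1scc(CN2CCN(c3cccc(F)c3)CC2)c1C(=O)c1cccc(C(F)(F)F)c1` gives 0%

On these two numbers compound 1 stands highest, but its nearest neighbour, compound 2, lies only slightly lower, a gap within the scatter of this assay, so the two cannot be ordered and both sit at the bottom of the scale. Compound 3 `Nc1scc(CN2CCN(C3CCCCCC3)CC2)c1C(=O)c1ccc(Cl)cc1` has not been measured. It differs from compound 1 in one place: cycloheptyl in place of 4-nitrophenyl on an amine nitrogen in a ring. For the measured compounds named here, no measured pair shows this change, so its effect is unknown and the expectation rests on compound 1 alone. Going by the values given here, because compound 1 gives 2% and the change has no measured precedent, the expected step is small, probably none beyond the scatter: a number 3 percentage points higher from compound 1 to compound 3 (within the scatter). For compound 3 the estimated value in this assay is 5%, with a range from -10% to 25%.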

Compound 3, a percentage reported as inhibition, at one concentration (the size of the read-out at that concentration, not a potency): 0%
For compound 3 the middle estimate is 5 percentage points above the measured one; the measured number falls inside the stated range.
By their numbers in this assay, from the lowest: compounds 2, 3 and 1 (each within the scatter of the next).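

At this position, on an amine nitrogen in a ring, cycloheptyl in place of 4-nitrophenyl gives a number 2 percentage points lower from compound 1 to compound 3 (within the scatter) in this assay, so the change now has a measured precedent. Exchanging an aromatic ring that carries hydrogen-bond acceptors for a seven-membered non-aromatic carbon ring leaves the read-out at the bottom of the scale, and with values this low the pair cannot show how much this position matters. Nothing at hand bears on the reason for this result.

As far as these compounds go, it remains open whether a different group on this nitrogen, such as a benzyl group, a longer alkyl chain or a chain ending in a carboxylic acid, would lift the read-out clear of the scatter. From the compounds shown here alone, it also remains open whether cycloheptyl would behave the same way with other groups elsewhere on the shared core.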